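Benzyloxy to Benzylsulfanyl: Estimating Compound 3

A few compounds are considered here, and "the series" means these few. Any claim that something is new, unique, unknown or untested is made for them only; others in the source may bear on it.

Measured so far:
- compound 1, `Clc1ccc2[nH]c(SCc3ccccc3OCc3ccccc3)nc2c1`, gives 3% in an assay on isolated protein for inhibition of Indoleamine 2,3-dioxygenase 1 (Homo sapiens), with a stated time of 60 min, tested at 10 uM; on this read-out higher numbers stand for more inhibition at the one concentration tested (going by the name of the read-out) and lower numbers for less inhibition
- compound 2, `O=S(=O)(Cc1ccccc1)c1ccccc1CSc1nc2cc(Cl)ccc2[nH]1`, gives 24% in this assay

Compound 1 stands lowest of the two numbers in this assay; compound 2 sits higher by a gap that lies beyond the usual scatter. Within the data shown here, no pair of measured compounds differs in one place, so nothing measured shows what a single change does here, and compound 2 differs from compound 1 in more than one respect.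

Compound 3, `Clc1ccc2[nH]c(SCc3ccccc3SCc3ccccc3)nc2c1`, is the unmeasured compound. It differs from compound 1 as follows:

benzylsulfanyl in place of benzyloxy on an aromatic carbon

With only compound 1 to build on, the expected step from compound 1 to compound 3 is small and upward, and may well stay within the scatter. Compound 3 is therefore estimated to give 10% in this assay, between 0% and 28%. The estimated step is a number 7 percentage points higher from compound 1 to compound 3 (within the scatter).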

Compound 3, a percentage reported as inhibition, at one concentration (the size of the read-out at that concentration, not a potency): 19%
Estimate against measurement, compound 3: 9 percentage points below; the range from low to high includes it.
By their numbers in this assay, from the lowest: compound 1; then compounds 3 and 2 (each within the scatter of the next).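

In this assay, among these compounds, benzylsulfanyl in place of benzyloxy on an aromatic carbon, ortho to a large group, gives the first step in one place, a number 16 percentage points higher from compound 1 to compound 3 (beyond the scatter). The leaving and entering groups have the same counts of heavy atoms, donors and acceptors and differ only in oxygen against sulfur, so this position responds to a change that leaves those counts untouched. Nothing available explains why the read-out moves.

This single exchange does not show whether the step would hold on another core or with another substituent on the benzyl ring. It also leaves open how this position would respond to a longer chain on the sulfur, or to an amine or a carboxylic acid in place of benzylsulfanyl.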